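The source may hold more compounds than are shown below. What is called first, only, known or untested is meant among the compounds shown, and "the series" means these compounds.

The three measured compounds share one core and differ only in the ring attached to an aromatic carbon of it. Compound 1 `NC(=O)c1cn(-c2ccc(O)cc2Cl)c2cc(-c3ccoc3)ccc2c1=O` carries a furan-3-yl there, and in an assay on isolated protein for inhibition of Calpain-1 catalytic subunit (Homo sapiens) (a lower number here means a stronger inhibitor, a higher number a weaker inhibitor), compound 1 gives 2000 nM. Compound 2 `NC(=O)c1cn(-c2ccc(O)cc2Cl)c2cc(-c3cccnn3)ccc2c1=O` carries a pyridazin-3-yl, and in this assay compound 2 gives 2000 nM; the step of no change at the digits printed from compound 1 to compound 2 (within the scatter) separates these two by nothing. Compound 3 `NC(=O)c1cn(-c2ccc(O)cc2Cl)c2cc(-c3ccccn3)ccc2c1=O` carries a pyridin-2-yl, and in this assay compound 3 gives 30000 nM, the highest of the three numbers: the steps of a 15-fold higher number from compound 1 to compound 3 (1.18 log units; beyond the scatter) and a 15-fold higher number from compound 2 to compound 3 (1.18 log units; beyond the scatter) are both large and beyond the scatter. Compound 4 `NC(=O)c1cn(-c2ccc(O)cc2Cl)c2cc(-c3ccnc(F)c3)ccc2c1=O` has not yet been measured; it comes from compound 3 by the change (2-fluoropyridin-4-yl in place of pyridin-2-yl on an aromatic carbon). No measured step involves a fluorinated pyridinyl, so the evidence that bears on it is that pyridin-2-yl at this place gave a far higher number than either other ring, as shown by the step of a 15-fold higher number from compound 1 to compound 3 (1.18 log units; beyond the scatter). Going by the values given here, compound 4 leaves pyridin-2-yl behind, so a lower number than for compound 3 is expected in this assay; its size is uncertain, as no step between two pyridinyl rings exists. The expected step is a 5.0-fold lower number from compound 3 to compound 4 (0.70 log units; beyond the scatter). For compound 4 the estimate is 6000 nM, within a range from 1500 nM to 30000 nM.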

Compound 4, half-maximal inhibitory concentration: 30000 nM
Compound 4: middle estimate off by 5.0-fold (0.70 log units), on the low side, within the range that was stated.
By their numbers in this assay, from the lowest: compounds 1 and 2 (each within the scatter of the next); then compounds 3 and 4 (each within the scatter of the next).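

In this assay the step of no change at the digits printed from compound 3 to compound 4 (within the scatter) shows that, on this aromatic carbon of the shared core, replacing pyridin-2-yl with 2-fluoropyridin-4-yl does not bring the number back toward those of the furan-3-yl and pyridazin-3-yl compounds. The high number is therefore not peculiar to pyridin-2-yl, since the step of a 15-fold higher number from compound 1 to compound 4 (1.18 log units; beyond the scatter) and the step of a 15-fold higher number from compound 2 to compound 4 (1.18 log units; beyond the scatter) set compound 4 as far from the two lower compounds as compound 3 stands, and among these four compounds both pyridinyl rings fall on the high side with no compound going against that split. No available evidence explains why these two rings give the same result or why they differ from the furan-3-yl and pyridazin-3-yl rings.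

The change from compound 3 to compound 4 alters both the point of attachment of the pyridine ring and the presence of fluorine, so the compounds shown do not separate these two changes; an unsubstituted pyridin-4-yl would do so. From the compounds shown here alone, it also remains open how a plain phenyl ring, or a pyridine ring carrying an amine or a methoxy group in place of fluorine, would fare at this position.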